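The compounds below may be only part of what the source reports. "The series", "measured", "known", "first", "only" and "open" are said of these compounds alone.

Measured so far in an ADME assay on HEK293 cells (Homo sapiens) for cytotoxicity, read by MTT assay, with a stated time of 48 h; a lower number here means a stronger inhibitor, a higher number a weaker inhibitor:
Compound 1 `N#Cc1nc2c(-c3nc4ccccc4[nH]3)c(N)n(CCN3CCCC3)c2nc1C#N`: 18300 nM
Compound 2 `N#Cc1nc2c(-c3nc4ccccc4[nH]3)c(N)n(CCO)c2nc1C#N`: > 50000 nM, a limit

Compound 2 is known only as a limit, and it sits at the limit of > 50000 nM in this assay, at which 1 of the 2 values shown sits.

Compound 3 `CCN(CC)CCCCn1c(N)c(-c2nc3ccccc3[nH]2)c2nc(C#N)c(C#N)nc21` has not yet been measured. It differs from compound 2 at one place: 2-(diethylamino)ethyl in place of hydroxy on a saturated chain carbon, two bonds along the chain from an aromatic nitrogen. In words, this is 2-(diethylamino)ethyl in place of hydroxy on a saturated chain carbon, two bonds along the chain from an aromatic nitrogen.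

Within the data shown here, one measured step bears on this change, made at the same place: an at least 2.7-fold higher number from compound 1 to compound 2 (0.43 log units; beyond the scatter), with hydroxy in place of pyrrolidin-1-yl. The new change runs the other way, from hydroxy to a chain carrying an amine nitrogen. A move to a lower number in this assay is therefore expected, of a size comparable to that one step, with compound 1 at 18300 nM as the nearest guide. This expectation rests on a single pair, and that step has only a limit at one end.

The estimated change is an at least 3.1-fold lower number from compound 2 to compound 3 (0.49 log units; beyond the scatter).

For compound 3 the estimated value is 16000 nM, with an expected range of 6000 nM to 42000 nM.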

Compound 3, half-maximal inhibitory concentration: 5370 nM
Beside the measured number, compound 3's estimate is 3.0-fold (0.47 log units) above it, and the stated range ends above it.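

In this assay, the place on a saturated chain carbon, two bonds along the chain from an aromatic nitrogen, now separates two amine-bearing groups and not just an amine from hydroxy: 2-(diethylamino)ethyl in place of pyrrolidin-1-yl gives a 3.4-fold lower number from compound 1 to compound 3 (0.53 log units; beyond the scatter). Putting 2-(diethylamino)ethyl in place of hydroxy gives an at least 9.3-fold lower number from compound 2 to compound 3 (0.96 log units; beyond the scatter), so the presence of an amine in the chain does not fix the value on its own, as the two amine-bearing compounds lie apart beyond the scatter. Compound 2 is known only as a limit, so the step from it has a bound and no exact size: the limit of > 50000 nM in this assay, at which 1 of the 3 values shown sits.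

The step between compound 1 and compound 3 changes the amine and the chain together, so the compounds shown cannot say which part carries it; diethylamino on the chain of compound 1, or pyrrolidin-1-yl on the 4-(diethylamino)butyl chain, would separate the two. Going by these compounds, whether the trend extends to a morpholine, a primary amine, a carboxylic acid or a still longer chain at this place also stays open.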